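The source may hold more compounds than are shown below. What is called first, only, known or untested is meant among the compounds shown, and "the series" means these compounds.

Three compounds share one core and have been compared in an assay on cells (Oocyte) for inhibition of pannexin-1 (Mus musculus), read by voltage clamp, tested at 50 uM, in the presence of a further agent that is not named here; a higher number here means more inhibition at the concentration tested (going by the name of the read-out), a lower number less inhibition. Compound 1 `O=C(O)c1cc2cc([N+](=O)[O-])ccc2n1CCCc1ccccc1` gives 65.5% in this assay. Compound 2 `O=C(O)c1cn(Cc2ccccc2)c2ccc(N(Cc3ccccc3)Cc3ccccc3)cc12` gives 19.5%. Compound 3 `O=C(O)c1cc2cc([N+](=O)[O-])ccc2n1Cc1ccccc1` gives 51.3%, which places it second highest of the three numbers: nearest is compound 1, and furthest is compound 2. For the measured compounds named here, the single one-place step among them, a number 14.2 percentage points lower from compound 1 to compound 3 (beyond the scatter), is a modest fall.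

Compound 4 `O=C(O)c1ccc(Cn2c(C(=O)O)cc3cc([N+](=O)[O-])ccc32)cc1` differs from compound 3 in one place: carboxy in place of hydrogen on an aromatic carbon. No measured step touches this kind of change; the only step shown swaps the length of the chain between the aromatic nitrogen and the phenyl, and says nothing about a carboxy entering on the phenyl. The expectation therefore rests on compound 3 alone, with a wide range. In this assay compound 4 is expected to show a step of a number 1.3 percentage points lower from compound 3 to compound 4 (within the scatter), that is no change beyond the scatter. The estimate for compound 4 is 50%, between 28% and 70%.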

Compound 4, a percentage reported as inhibition, at one concentration (the size of the read-out at that concentration, not a potency): 61%
Compound 4: the middle estimate sits 11 percentage points below what was measured; measured number inside the range.
By their numbers in this assay, from the lowest: compound 2; then compounds 3, 4 and 1 (each within the scatter of the next, the first and the last beyond it).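

Carboxy in place of hydrogen on an aromatic carbon, para to a large group, gives in this assay a number 9.7 percentage points higher from compound 3 to compound 4 (within the scatter). For the compounds shown here, the only earlier step concerned the chain joining the aromatic nitrogen to the phenyl, so this is the first sign that the ring itself can carry a new group, here with one more hydrogen-bond donor and acceptor, without a change beyond the scatter. No measurement shown gives a reason for this result.

The compounds shown leave open whether an amine or a methyl ester on the same aromatic carbon would read like the carboxy. They also leave open whether the carboxy would fit as well on another carbon of that ring, or on the longer phenethyl chain of compound 1.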